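The source may report more compounds than this note shows. Statements on the series, on what has been measured and on what is new or still open speak of the compounds shown alone.

Of the compounds shown here, three built on one shared core have been measured in an assay on isolated protein for agonist activity at Bile acid receptor (Homo sapiens), read by AlphaScreen, with a stated time of 30 min; on this read-out higher numbers stand for larger maximal responses and lower numbers for smaller maximal responses. Compound 1 `Cc1ccccc1-n1nc(C)c2c1NC(=O)[C@H](C)S[C@@H]2c1ccc(-c2ccccc2)cc1` gives 24%. Compound 2 `CCOc1cccc(-c2ccc([C@H]3S[C@@H](C)C(=O)Nc4c3c(C)nn4-c3ccccc3C)cc2)c1` gives 13%, and a number 11 percentage points lower from compound 1 to compound 2 (beyond the scatter). Compound 3 `COc1ccc(Oc2ccc([C@H]3S[C@@H](C)C(=O)Nc4c3c(C)nn4-c3ccccc3C)cc2)cc1` gives 70%, the highest of the three numbers: a number 46 percentage points higher from compound 1 to compound 3 (beyond the scatter), and a number 57 percentage points higher from compound 2 to compound 3 (beyond the scatter). Compound 4 `COc1ccccc1Oc1ccc([C@H]2S[C@@H](C)C(=O)Nc3c2c(C)nn3-c2ccccc2C)cc1` has not yet been measured in this assay. It differs from compound 3 in one place, (2-methoxyphenyl in place of 4-methoxyphenyl on an oxygen on an aromatic ring). Within the data shown here, no measured step relocates a methoxy group on the ring attached to the oxygen, so the change has no direct precedent. Among the measured compounds shown here, the steps that bear on it, a number 46 percentage points higher from compound 1 to compound 3 (beyond the scatter) and a number 57 percentage points higher from compound 2 to compound 3 (beyond the scatter), show that the group on the oxygen on an aromatic ring carries most of the response, while a number 11 percentage points lower from compound 1 to compound 2 (beyond the scatter) shows that altering the outer ring of the earlier biphenyl can lower the number. Compound 4 keeps the 4-methoxyphenoxy-type linkage through the oxygen, so a large loss is not expected, but some decline is plausible. Compound 4 is therefore expected to give 55%, within a range from 30% to 80%. This estimate corresponds to an expected step of a number 15 percentage points lower from compound 3 to compound 4 (beyond the scatter), a modest decline that may not clear the scatter.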

Compound 4, largest response reached (reported as efficacy), in percent of the reference or control that the assay uses: 240%
Beside the measured number, compound 4's estimate is 185 percentage points below it, outside the stated range (above it).
By their numbers in this assay, from the lowest: compound 2; then compound 1; then compound 3; then compound 4.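

In this assay, among these compounds, 2-methoxyphenyl in place of 4-methoxyphenyl on an oxygen on an aromatic ring gives a number 170 percentage points higher from compound 3 to compound 4 (beyond the scatter), even though the two groups have the same atoms and the same counts, so the place of the methoxy group on this ring can matter as much as the choice of group, which the earlier compounds could not show. The 2-methoxyphenoxy group also goes well beyond what 4-methoxyphenoxy achieved against the same starting points: a number 216 percentage points higher from compound 1 to compound 4 (beyond the scatter) in place of phenyl, set against a number 46 percentage points higher from compound 1 to compound 3 (beyond the scatter), and a number 227 percentage points higher from compound 2 to compound 4 (beyond the scatter) in place of 3-ethoxyphenyl, set against a number 57 percentage points higher from compound 2 to compound 3 (beyond the scatter). Nothing available here accounts for this large response from a change that leaves the atoms the same.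

The compounds shown leave open how a 3-methoxyphenoxy group would compare with its two isomers, and whether the response would hold with an ethoxy group, a fluorine or an amine in place of the methoxy group of 2-methoxyphenoxy. They also leave open whether the oxygen itself is needed, as a methylene or an amine in that link would test.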